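Compound 2 to compound 4: a side chain exchanged on the amide

The source may report more compounds than this note shows. Statements on the series, on what has been measured and on what is new or still open speak of the compounds shown alone.

Compound 1 `COc1cc2c(cc1O)CCC(C)(CC(=O)O)O2`, compound 2 `COc1cc2c(cc1O)CCC(C)(CC(=O)N[C@H](C(=O)O)C(C)C)O2` and compound 3 `COc1cc2c(cc1O)CCC(C)(CC(N)=O)O2` share one core and differ only in the group on the carbonyl carbon. In an ADME assay on SH-SY5Y cells (Homo sapiens) for cytotoxicity, read by MTT assay, with a stated time of 24 h, tested at 25 uM (a lower number here means a stronger effect, a higher number a weaker effect of the compound at the concentration tested), compound 1 gives 92.5%, compound 3 gives 100% and compound 2 gives 76.1%, the lowest of the three: a number 16.4 percentage points lower from compound 1 to compound 2 (beyond the scatter) and a number 23.9 percentage points higher from compound 2 to compound 3 (beyond the scatter), while a number 7.5 percentage points higher from compound 1 to compound 3 (within the scatter). Compound 4 `COc1cc2c(cc1O)CCC(C)(CC(=O)N[C@@H](CCC(N)=O)C(=O)O)O2`, not yet measured, differs from compound 2 by 2-carbamoylethyl in place of isopropyl on a saturated chain carbon bound to an amide-type nitrogen and a carbonyl carbon. Going by the values given here, no measured step touches that chain carbon; the two steps that altered the group on the amide-type nitrogen were modest. The step of a number 5.9 percentage points higher from compound 2 to compound 4 (within the scatter) is therefore expected to be small, probably within the scatter. Compound 4 is estimated at 82%, in the range 68% to 100%.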

Compound 4, a percentage reported as activity, at one concentration (the size of the read-out at that concentration, not a potency): 91.8%
The estimate for compound 4 lay 9.8 percentage points below the measured number, and the stated range covers the measured number.
By their numbers in this assay, from the lowest: compound 2; then compounds 4, 1 and 3 (each within the scatter of the next).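

In this assay, going by these compounds alone, the saturated chain carbon bound to an amide-type nitrogen and a carbonyl carbon proves sensitive to its substituent: 2-carbamoylethyl in place of isopropyl gives a step beyond the scatter (a number 15.7 percentage points higher from compound 2 to compound 4 (beyond the scatter)), which the earlier compounds, varied only on the carbonyl carbon or the amide-type nitrogen, could not show. A substituted amide-type nitrogen therefore need not separate a compound from the unsubstituted amide (a number 8.2 percentage points lower from compound 3 to compound 4 (within the scatter)). Nothing available explains this step.

Whether the carbamoyl group or the two-carbon stretch carrying it accounts for the step stays open. So does how an aminoethyl or a phenyl group would behave on this chain carbon.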